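Amide ring swap: furan-3-yl to 1,3-thiazol-5-yl

The compounds below may be only part of what the source reports. "The series", "measured", "known", "first", "only" and "open" are said of these compounds alone.

The compounds share one core and differ only in the group on the carbonyl carbon of the amide. In a functional assay on MKN-7 cells (Homo sapiens) for inhibition, read by colorimetric assay and sulforhodamine B assay, with a stated time of 48 h (on this read-out higher numbers stand for weaker inhibition of growth and lower numbers for stronger inhibition of growth), compound 1 (`CCCCCCCCCCCC[C@@H](O)[C@H]1CC[C@H]([C@H](O)CCCCCCCCCCNC(=O)c2cccs2)O1`), with thiophen-2-yl, gives 269 nM. Compound 2 (`CCCCCCCCCCCC[C@@H](O)[C@H]1CC[C@H]([C@H](O)CCCCCCCCCCNC(=O)c2ccco2)O1`), with furan-2-yl, gives 832 nM. Compound 3 (`CCCCCCCCCCCC[C@@H](O)[C@H]1CC[C@H]([C@H](O)CCCCCCCCCCNC(=O)c2ccoc2)O1`), with furan-3-yl, gives 372 nM. Its position is set by two steps: a 1.4-fold higher number from compound 1 to compound 3 (0.14 log units; within the scatter), and a 2.2-fold lower number from compound 2 to compound 3 (0.35 log units; beyond the scatter).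

Compound 4 (`CCCCCCCCCCCC[C@@H](O)[C@H]1CC[C@H]([C@H](O)CCCCCCCCCCNC(=O)c2cncs2)O1`) carries 1,3-thiazol-5-yl in place of furan-3-yl on a carbonyl carbon.

No 1,3-thiazol-5-yl amide has been measured, so only the three exchanges at this same place bear on the change. The larger two are modest: a 3.1-fold higher number from compound 1 to compound 2 (0.49 log units; beyond the scatter), and a 2.2-fold lower number from compound 2 to compound 3 (0.35 log units; beyond the scatter). The third stays within the scatter. With so narrow a spread among these groups, no step beyond the scatter is expected in this assay, and no firm direction can be assigned. The expected change is a 1.1-fold higher number from compound 3 to compound 4 (0.03 log units; within the scatter). Compound 4 is estimated at 400 nM, with an expected range of 170 nM to 950 nM.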

Compound 4, concentration for 50% growth inhibition: 617 nM
Compound 4: the middle estimate sits 1.5-fold (0.19 log units) below what was measured; measured number inside the range.
By their numbers in this assay, from the lowest: compounds 1, 3, 4 and 2 (each within the scatter of the next, the first and the last beyond it).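

At this amide position, the 1,3-thiazol-5-yl group puts a second hetero atom into the five-membered aromatic ring, and in this assay the exchange for furan-3-yl gives a 1.7-fold higher number from compound 3 to compound 4 (0.22 log units; within the scatter), while the exchange for furan-2-yl gives a 1.3-fold lower number from compound 2 to compound 4 (0.13 log units; within the scatter), both within the scatter. Going by these compounds alone, the one step from the new amide that lies beyond the scatter is modest: a 2.3-fold higher number from compound 1 to compound 4 (0.36 log units; beyond the scatter). Compound 1 and compound 4 both carry a ring sulfur, yet they do not fall together, so a ring sulfur alone does not set the number in this small set, and compound 4 cannot be told apart from either furan. No measurement on hand accounts for these differences.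

The compounds shown leave open whether a phenyl or pyridine ring on the carbonyl carbon would stay within the same narrow spread as these five-membered rings. They also leave open whether a non-aromatic group there, such as a piperidine or a simple acetyl, would give a larger step than any seen among these rings.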